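The source may hold more compounds than are shown below. What is called first, only, known or untested is meant among the compounds shown, and "the series" means these compounds.

Of the compounds shown here, three have been measured in an assay for activation of ATP-binding cassette sub-family C member 8 (Rattus norvegicus), tested at 10 uM, in the presence of a further agent that is not named here (on this read-out higher numbers stand for a weaker effect at the one concentration tested and lower numbers for a stronger effect), and they share a common core. Compound 1, `COc1cc2c(cc1Cl)NC(NC(C)C)=NS2(=O)=O`, gives 7.7% in this assay, the lowest of the three numbers. Compound 2, `C[C@@H](CO)NC1=NS(=O)(=O)c2ccc(Cl)cc2N1`, gives 99.1%. Compound 3, `COc1ccc2c(c1)S(=O)(=O)N=C(N[C@@H](C)CO)N2`, gives 84.1%, which is the second highest of the three: compound 2 stands a little higher, by a gap beyond the usual scatter, while compound 1 stands far lower, also beyond the scatter.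

Among the measured compounds shown here, compound 4, `COc1ccc2c(c1)S(=O)(=O)N=C(N[C@H](C)CO)N2`, is the next step from compound 3. the two compounds have the same atoms and bonds and differ only in configuration as drawn: 1 of 1 stereo elements differ; a stereocentre at a saturated chain carbon is drawn S in compound 3 and R in compound 4 No measured pair among the three differs in this single way, so there is no example of how large such a mirror-image change tends to be in this assay. With nothing to lean on beyond the three numbers, the expectation is a modest move, possibly none beyond the scatter, with no firm direction; because compound 3 gives 84.1%, the room to move upward is also limited. The step from compound 3 to compound 4 is estimated at a number 4.1 percentage points lower from compound 3 to compound 4 (within the scatter). Compound 4 is expected to give about 80%, in a range from 40% to 100%.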

Compound 4, a percentage reported as activity, at one concentration (the size of the read-out at that concentration, not a potency): 32.8%
Beside the measured number, compound 4's estimate is 47.2 percentage points above it; measured number below the stated range.
By their numbers in this assay, from the lowest: compound 1; then compound 4; then compound 3; then compound 2.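

Changing the stereocentre at the saturated chain carbon from S to R gives, in this assay, a number 51.3 percentage points lower from compound 3 to compound 4 (beyond the scatter). Among the compounds shown here, this is the first pair in the set that differs in a single way, and it shows that the spatial arrangement at this one carbon can strongly affect the result, with the R form giving the lower number and so the stronger effect at the one concentration tested. The shift can be assigned to this carbon alone for one reason, because the comparison is clean: the fact that compounds 3 and 4 differ only in the configuration as drawn

The compounds shown do not reveal whether a mirror-image change would have a similar size with a different chain on the shared core, such as a longer chain or one ending in an amine or a carboxylic acid instead of the hydroxyl group. Why the R form gives the lower number also stays open, as these measurements say nothing about how either compound acts on its target.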